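The source may hold more compounds than are shown below. What is called first, only, known or untested is meant among the compounds shown, and "the series" means these compounds.

In an ADME assay on microsomes from liver (Canis lupus familiaris) for metabolic stability, read by LC-MS, using NADPH, with a stated time of 10 min, tested at 0.1 uM (on this read-out higher numbers stand for fast clearance and lower numbers for slow clearance), compound 1 `COc1ccc(F)cc1N1C(=O)CSC1c1cccc(C(=O)NCCCCn2cccn2)c1` gives 480 mL.min-1.g-1 and compound 2 `O=C(NCCCCc1ccccc1)c1cccc(C2SCC(=O)N2c2cccc(-c3c[nH]nn3)c2)c1` gives 226 mL.min-1.g-1 as its read-out. Compound 2 therefore holds the lower of the two numbers, and the gap between them lies beyond the usual scatter. Compound 3 `O=C(NCCCCc1ccccc1)c1cccc(C2SCC(=O)N2c2ccccc2F)c1` differs from compound 2 in one place: a group of 7 heavy atoms (6 carbon, 1 fluorine; one six-membered aromatic ring of carbon only) in place of a group of 11 heavy atoms (8 carbon, 3 nitrogen; one five-membered aromatic ring with 3 hetero atoms, one six-membered aromatic ring of carbon only), on an amide-type nitrogen in a ring and the group that enters there is 2-fluorophenyl. Among the measured compounds shown here, no measured pair shows this change, so the expectation rests on few data. For the measured compounds named here, compound 1 at 480 mL.min-1.g-1 also has no five-membered aromatic ring with 3 hetero atoms on that nitrogen, and it is the only guide available. An upward step a 1.9-fold higher number from compound 2 to compound 3 (0.27 log units; within the scatter) is therefore expected in this assay toward faster clearance, of about the size of the usual scatter. For compound 3 the estimated value is 420 mL.min-1.g-1 with an expected range from 200 mL.min-1.g-1 to 850 mL.min-1.g-1 in that assay.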

Compound 3, intrinsic clearance in microsomes: 815 mL.min-1.g-1
Estimate against measurement, compound 3: 1.9-fold (0.29 log units) below, and the stated range covers the measured number.
By their numbers in this assay, from the lowest: compound 2; then compounds 1 and 3 (each within the scatter of the next).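

Among the compounds shown here, compound 3 gives the first pair in which only the group on the amide-type nitrogen in a ring changes: in this assay, 2-fluorophenyl in place of the larger group carrying a five-membered aromatic ring with 3 hetero atoms gives a 3.6-fold higher number from compound 2 to compound 3 (0.56 log units; beyond the scatter). This shows that, with the rest of the molecule held constant, the read-out responds to the group at this position, and the step lies toward faster clearance. Nothing shown here offers an explanation for this step.

The pair leaves open whether the step follows the loss of the five-membered aromatic ring or the arrival of the fluorine, as both changes fall together. As far as these compounds go, how a plain phenyl or a phenyl bearing a carboxylic acid on this nitrogen would read in this assay also remains open.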